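The compounds below may be only part of what the source reports. "The series", "measured", "known", "first", "only" and "open" are said of these compounds alone.

Measured so far:
- Compound 1, `COc1cc(O)c(C(=O)/C=C/c2ccc(F)cc2)c(OC)c1`: "not active" (no number reported) in a functional assay on HaCaT cells (Homo sapiens), read by fluorescence and BrdU incorporation, with a stated time of 48 h, tested at 25 uM; a lower number here means a stronger effect, a higher number a weaker effect of the compound at the concentration tested
- Compound 2, `COc1cc(OC)c(C(=O)/C=C/c2ccccc2)c(OC)c1`: 0.1%

For the measured compounds named here, compound 2 is the only one of the pair with a number attached. In this assay compound 2 gives 0.1%, a read-out so small that, at the single concentration tested, the compound does essentially nothing that the assay can pick up. Going by the values given here, compound 1 carries no number at all; it is simply recorded as showing no effect, so the two measured compounds sit together at the bottom of the scale, and no step between them can be stated beyond that.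

The next compound, compound 3, `COc1cc(OC)c(C(=O)/C=C/c2ccc(F)cc2)c(OC)c1`, is reached from compound 2 by a single change: fluoro in place of hydrogen on an aromatic carbon. Fluoro replaces hydrogen on the aromatic ring that hangs at the far end of the shared core, while everything else in compound 2 stays as it is.

Among the compounds with values here, with no measured pair showing what this swap does here, and with compound 2 already at the floor of the assay, no step beyond the usual scatter is expected in either direction; the expected step is a number 1.9 percentage points higher from compound 2 to compound 3 (within the scatter). Compound 3 is therefore estimated at 2%, with a range from 0% to 15%.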

Compound 3, a percentage reported as activity, at one concentration (the size of the read-out at that concentration, not a potency): 0.4%
Compound 3: middle estimate off by 1.6 percentage points, on the high side; measured number inside the range.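

In this assay, for the compounds shown here, the change from phenyl to 4-fluorophenyl gives a number 0.3 percentage points higher from compound 2 to compound 3 (within the scatter), the first measured step for any change. It shows that placing a fluoro group on this aromatic ring, para to a large group, does not move the read-out beyond what repeated measurements would scatter by, at least when the rest of the molecule is that of compound 2. Both compounds sit at the very bottom of the scale, however, so this pair cannot show how the same swap would behave in a compound with a clearly larger read-out, and no measurement shown here offers an explanation for the result.

The compounds shown leave open whether a different group at this place, such as an amine, a carboxylic acid or a longer chain, would lift the number away from the bottom of the scale in this assay. They also leave open whether a fluoro group elsewhere on this ring would behave as it does here.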